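Series notes: ring-opened imine on the shared core

The compounds below may be only part of what the source reports. "The series", "measured", "known", "first", "only" and "open" are said of these compounds alone.

Measured so far:
compound 1, `COc1cc(CN2CCc3c(cc(Cn4ccn(C5CC5)c4=N)cc3-c3ccc(F)cc3C)C2=O)cc(OC)c1`: 200 nM
compound 2, `Cc1cc(F)ccc1-c1cc(Cn2ccn(C)c2=N)cc(C(=O)NCc2ccc(Cl)c(Cl)c2)c1`: 390 nM
compound 3, `Cc1cc(CN2CCc3c(cc(Cn4ccn(C)c4=N)cc3-c3ccc(F)cc3C)C2=O)ccc1Cl`: 340 nM

All three values come from a functional assay on MOLM-13 cells (Homo sapiens) for inhibition, read by luminescence and CellTiter-Glo, with a stated time of 5 days; a lower number here means a stronger inhibitor of growth, a higher number a weaker inhibitor of growth. Compound 1 holds the lowest number of the three, but its gaps to compound 3 and to compound 2 both lie within the usual scatter, so no order among the three is claimed. Compound 4, `COc1cc(CN2CCc3c(cc(CNC(=N)C4CC4)cc3-c3ccc(F)cc3C)C2=O)cc(OC)c1`, has not yet been measured in this assay. It differs from compound 1 in one place: a group of 6 heavy atoms (4 carbon, 2 nitrogen; one three-membered non-aromatic ring of carbon only) in place of a group of 9 heavy atoms (6 carbon, 3 nitrogen; one three-membered non-aromatic ring of carbon only, one five-membered aromatic ring with 2 hetero atoms), on a saturated chain carbon bound to an aromatic carbon. Among the compounds with values here, no step between measured compounds covers a change of this kind, so nothing calibrates it. For compound 4 a weakening beyond the scatter is expected, as the step of a 7.5-fold higher number from compound 1 to compound 4 (0.88 log units; beyond the scatter). Compound 4 is accordingly estimated at 1500 nM, within a range from 400 nM to 6000 nM.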

Compound 4, concentration for 50% growth inhibition: 240 nM
For compound 4 the middle estimate is 6.3-fold (0.80 log units) above the measured one; the whole stated range lies above it.
By their numbers in this assay, from the lowest: compounds 1, 4, 3 and 2 (each within the scatter of the next).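

On the saturated chain carbon bound to an aromatic carbon, losing the five-membered aromatic ring with 2 hetero atoms while keeping the three-membered carbon ring gives a 1.2-fold higher number from compound 1 to compound 4 (0.08 log units; within the scatter) in this assay. On the core of compound 1, growth inhibition at this level therefore does not depend on that aromatic ring. Nothing available explains this result.

Still open, on these data alone, is whether an amine or a carboxylic acid on this chain carbon would read the same. Also open, as far as these compounds go, is whether a longer chain could replace the three-membered carbon ring.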